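The source may hold more compounds than are shown below. What is called first, only, known or untested is meant among the compounds shown, and "the series" means these compounds.

Working notes on the series. Compound 1 `C=CCOc1ccc(C(=O)Nc2cccc(Br)n2)cc1` gives 65500 nM in an in vitro assay on HEK-tsA201 cells for antagonist activity at Neuronal acetylcholine receptor; alpha3/beta4 (Homo sapiens), read by fluorescence and calcium flux; on this read-out higher numbers stand for weaker inhibition and lower numbers for stronger inhibition. Compound 2 `CCCOc1ccc(C(=O)Nc2cccc(Cl)n2)cc1` reaches only the assay limit, > 100000 nM, in this assay. Compound 3 `CCCNc1cccc(NC(=O)c2ccc(OCCC)cc2)n1` gives 12600 nM in this assay, the lowest of the two numbers shown, with compound 1 the nearest. Among the measured compounds shown here, the one step within the set, an at least 7.9-fold lower number from compound 2 to compound 3 (0.89 log units; beyond the scatter), runs against the limit of > 100000 nM in this assay, at which 1 of the 3 values shown sits, and therefore tells only the least its size can be.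

Compound 4 `CCCOc1ccc(C(=O)Nc2cccc(Nc3cccc(F)c3)n2)cc1` differs from compound 3 by 3-fluorophenyl in place of propyl on a nitrogen on an aromatic ring. For the measured compounds named here, no measured step touches this exchange: the only measured step, an at least 7.9-fold lower number from compound 2 to compound 3 (0.89 log units; beyond the scatter), changes the group on the aromatic carbon, not the substituent on the amino nitrogen, so it sets no direction for the new change. With nothing to lean on, the expected step from compound 3 to compound 4, a 1.3-fold lower number from compound 3 to compound 4 (0.10 log units; within the scatter), is taken as small, within the scatter, and the range kept wide. Compound 4 is accordingly estimated at 10000 nM in this assay, with a range from 2500 nM to 40000 nM.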

Compound 4, half-maximal inhibitory concentration: > 100000 nM
Compound 4: a limit, no number (the forecaster's own chance of this, stated with the estimate: 15%); middle value at least 10-fold (1.00 log units) from the limit.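

In this assay, 3-fluorophenyl in place of propyl on the nitrogen gives an at least 7.9-fold higher number from compound 3 to compound 4 (0.89 log units; beyond the scatter), so an amino link at this position does not by itself keep the lower number seen with propylamino: the group on the nitrogen counts. Compound 4 gives > 100000 nM, which is a limit of the assay and not a number. The exchange of chloro for (3-fluorophenyl)amino cannot be read, and the exchange of propyl for 3-fluorophenyl has only a least size: the limit of > 100000 nM in this assay, at which 2 of the 4 values shown sit.

The compounds shown leave open whether the aromatic ring or its fluorine goes with the higher number, which an unsubstituted phenyl or a benzyl on the same nitrogen would separate. They also leave open whether a butyl or other longer chain there would lower the number further than propyl.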